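Methoxy for methyl on the pendant ring of compound 3

A few compounds are considered here, and "the series" means these few. Any claim that something is new, unique, unknown or untested is made for them only; others in the source may bear on it.

Three compounds of this series have numbers in a functional assay on Jurkat cells (Homo sapiens) for activation, with a stated time of 24 h; on this read-out higher numbers stand for an effect only at larger amounts of compound and lower numbers for an effect already at smaller amounts. Compound 1 `Oc1ccccc1CNc1ccc(-c2ccccc2)cc1` gives 1820 nM. Compound 2 `Oc1ccccc1CNc1ccc(-c2cccc(Cl)c2)cc1` gives 6200 nM. Compound 3 `Cc1cccc(-c2ccc(NCc3ccccc3O)cc2)c1` gives 9190 nM, the highest of the three numbers; its step from compound 1 is a 5.0-fold higher number from compound 1 to compound 3 (0.70 log units; beyond the scatter), while compound 2 and compound 3 lie within the scatter of each other, a 1.5-fold higher number from compound 2 to compound 3 (0.17 log units; within the scatter).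

Compound 4 `COc1cccc(-c2ccc(NCc3ccccc3O)cc2)c1` differs from compound 3 by methoxy in place of methyl on an aromatic carbon. Within the data shown here, no measured step exchanges one substituent for another at this position apart from a 1.5-fold higher number from compound 2 to compound 3 (0.17 log units; within the scatter), which stays within the scatter; the only steps beyond the scatter, a 3.4-fold higher number from compound 1 to compound 2 (0.53 log units; beyond the scatter) and a 5.0-fold higher number from compound 1 to compound 3 (0.70 log units; beyond the scatter), both put a group where hydrogen was. Among the measured compounds shown here, the exchange of methyl for methoxy has therefore no direct precedent here, and an expectation can only lean on the small gap between compound 2 and compound 3.

For compound 4 the expected step is a 1.0-fold lower number from compound 3 to compound 4 (0.01 log units; within the scatter), that is, no change beyond the scatter. Compound 4 is estimated in this assay at 9000 nM, within a range from 3500 nM to 23000 nM.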

Compound 4, half-maximal effective concentration: "not active" (no number reported)
Compound 4 has no reported number here; the estimate stays without a comparison.
By their numbers in this assay, from the lowest: compound 1; then compounds 2 and 3 (each within the scatter of the next).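

Among these compounds, compound 4 is reported as "not active" in this assay, without a number, so no step from compound 3 to compound 4 can be read. No measurement shown here bears on this result. The compounds shown leave open how far compound 4 lies from compound 3 on this read-out.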